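Pivaloyloxymethyl for acetyl on the shared core

The source may report more compounds than this note shows. Statements on the series, on what has been measured and on what is new or still open speak of the compounds shown alone.

Notes on the series built on compound 1 `CC(=O)c1c(C)nc2c(OCc3ccccc3)cccn12`. In a functional assay on the whole organism with Rattus norvegicus as the target, with a stated time of 4 h, at a dose of 40 mg/kg by the intraperitoneal route (on this read-out lower numbers stand for less inhibition and higher numbers for more inhibition at the one dose given (going by the name of the read-out)), compound 1 gives 57%, the second highest of the three numbers. Compound 2 `COCc1c(C)nc2c(OCc3ccccc3)cccn12` gives 99% in this assay, and compound 3 `Cc1nc2c(OCc3ccccc3)cccn2c1C[S+](C)[O-]` gives 0%. Compound 4 `Cc1nc2c(OCc3ccccc3)cccn2c1COC(=O)C(C)(C)C` is not yet measured; it differs from compound 1 by (((tert-butyl)carbonyl)oxy)methyl in place of acetyl on an aromatic carbon. The closest measured step is a number 42 percentage points higher from compound 1 to compound 2 (beyond the scatter), where methoxymethyl took the place of the acetyl; the step of a number 57 percentage points lower from compound 1 to compound 3 (beyond the scatter), however, shows that a change at the same aromatic carbon can also go the other way, and strongly. A rise is therefore expected, with wide uncertainty: the estimated step is a number 23 percentage points higher from compound 1 to compound 4 (beyond the scatter). Compound 4 is estimated at 80%, with a range from 40% to 100%.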

Compound 4, a percentage reported as inhibition, in the whole organism at one dose (the size of the read-out at that dose, not a potency): 48%
Beside the measured number, compound 4's estimate is 32 percentage points above it; the measured number falls inside the stated range.
By their numbers in this assay, from the lowest: compound 3; then compounds 4 and 1 (each within the scatter of the next); then compound 2.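

In this assay the step is a number 9 percentage points lower from compound 1 to compound 4 (within the scatter) and so (((tert-butyl)carbonyl)oxy)methyl at this aromatic carbon does not repeat the gain seen with methoxymethyl. The group on the oxygen alone matters strongly, with a number 51 percentage points lower from compound 2 to compound 4 (beyond the scatter) when (tert-butyl)carbonyl replaces methyl, yet the result remains clear of the sulfur-bearing compound with a number 48 percentage points higher from compound 3 to compound 4 (beyond the scatter) as the step. Nothing measured here accounts for these steps.

Still open, as far as these compounds go, is whether the high number of compound 2 is particular to methoxymethyl. Hydroxymethyl or aminomethyl at this carbon would bear on that.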